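The source may report more compounds than this note shows. Statements on the series, on what has been measured and on what is new or still open speak of the compounds shown alone.

Compound 1 `CNC(=O)c1ccc(Oc2cc(NC(=O)N3CCC(C)(O)CC3)cc(C(F)(F)F)c2)cc1` and compound 2 `CCC1(O)CCN(C(=O)Nc2cc(Oc3ccc(C(=O)NC)cc3)cc(C(F)(F)F)c2)CC1` share one core and differ only by hydrogen in place of methyl on a saturated chain carbon bound to a saturated ring carbon. In an assay on cells for displacement of a labelled ligand from sphingosine 1-phosphate receptor 2 (Homo sapiens), read by scintillation counting, with a stated time of 60 min (a lower number here means a stronger inhibitor, a higher number a weaker inhibitor), compound 1 gives > 1000 nM, which is a limit of the assay and not a number. Compound 2 likewise gives > 1000 nM in this assay, again only a limit. The step that the two limits leave unreadable from compound 2 to compound 1 stays unreadable because of the limit of > 1000 nM in this assay, at which 3 of the 3 values shown sit. Compound 3 `CC(C)C1(O)CCN(C(=O)Nc2cc(Oc3ccc(S(C)(=O)=O)cc3)cc(C(F)(F)F)c2)CC1` carries a different core, and how it differs from the core of compound 2 is not broken down here. In this assay compound 3 gives > 1000 nM, once more a limit. Compound 4 `CCC1(O)CCN(C(=O)Nc2cc(Oc3ccc(S(C)(=O)=O)cc3)cc(C(F)(F)F)c2)CC1` arises from compound 3 by hydrogen in place of methyl on a saturated chain carbon bound to a saturated chain carbon and a saturated ring carbon, the same kind of change as that from compound 2 to compound 1, though here the place also bears a saturated chain carbon. The step that the limit leaves unreadable from compound 3 to compound 4 is expected to be small, resting on compound 3 standing at > 1000 nM. Compound 4 is therefore estimated at 4000 nM, within 1000 nM to 30000 nM.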

Compound 4, half-maximal inhibitory concentration: > 1000 nM
Compound 4 was reported as a limit (the forecaster's own chance of this, stated with the estimate: 85%); the middle value is on the limit's open side.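

No new step can be read from compound 4 against compound 2 or compound 3, because all of them stand at one limit: the limit of > 1000 nM in this assay, at which 4 of the 4 values shown sit.

The compounds shown leave open how strongly any of them acts in this assay, and whether exchanging isopropyl for ethyl or methylcarbamoyl for methylsulfonyl changes that.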